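The source may hold more compounds than are shown below. What is called first, only, known or untested is meant among the compounds shown, and "the series" means these compounds.

Compound 1, `Cc1nc2c([nH]1)C(=O)/C(=N/c1cccc(Br)c1)C(Cl)=C2O`, gives 1000 nM in an ADME assay (Rattus norvegicus) for inhibition; a higher number here means a weaker inhibitor, a lower number a stronger inhibitor.
Compound 2, `Cc1nc2c([nH]1)C(=O)/C(=N/c1cccc(Cl)c1Cl)C(Cl)=C2O`, gives 600 nM.
Compound 3, `O=C1C=C(Nc2ccc(Cl)cc2)C(=O)c2[nH]c(-c3ccccn3)nc21`, gives 13000 nM.

Among these three, compound 3 stands at the highest number, and both compound 1 and compound 2 lie clearly lower, beyond the usual scatter of repeated measurements. Compound 4, `O=C1C=C(Nc2ccc(Br)cc2)C(=O)c2[nH]c(-c3ccccn3)nc21`, shares the core of compound 3 and differs only in one place: bromo in place of chloro on an aromatic carbon. Among the compounds with values here, no pair of measured compounds shows this particular exchange, so the size of the step is not known from the data. A swap of one halogen for a neighbouring halogen at a single aromatic position is, on general experience, a small change, and the expected step in this assay is one within the scatter, in no firm direction. For compound 4 the estimated value is 11000 nM, with a range from 5000 nM to 25000 nM, which is a step expected to be a 1.2-fold lower number from compound 3 to compound 4 (0.07 log units; within the scatter).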

Compound 4, half-maximal inhibitory concentration: 12000 nM
Compound 4: middle estimate off by 1.1-fold (0.04 log units), on the low side, and the stated range covers the measured number.
By their numbers in this assay, from the lowest: compounds 2 and 1 (each within the scatter of the next); then compounds 4 and 3 (each within the scatter of the next).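

Within the data shown here, the step from 4-chlorophenyl to 4-bromophenyl, a 1.1-fold lower number from compound 3 to compound 4 (0.03 log units; within the scatter) in this assay, is the first exchange at a single place in this set, and it lies within the scatter. At this position on the aromatic ring, then, these two halogens cannot be told apart in this assay. No measured evidence bears on this result.

Still open, from the compounds shown here alone, is whether a group of another kind at the same position, such as an amine or a carboxylic acid, would move the number beyond the scatter. Going by these compounds, whether this exchange behaves alike on the core of compound 1 is also open.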